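Chloro replacement on the way to compound 4

The source may hold more compounds than are shown below. What is called first, only, known or untested is meant among the compounds shown, and "the series" means these compounds.

Measured in an ADME assay on HaCaT cells (Homo sapiens) for cytotoxicity, read by MTT assay, with a stated time of 48 h; a higher number here means a weaker inhibitor, a lower number a stronger inhibitor:
- compound 1 `Clc1ccc2[nH]c(-c3cn(-c4ccccc4)nc3-c3ccccc3)nc2c1`: > 50000 nM, a limit
- compound 2 `Clc1cc2nc(-c3cn(-c4ccccc4)nc3-c3ccccc3)[nH]c2cc1Cl`: 29700 nM
- compound 3 `Fc1ccc(-c2nn(-c3ccccc3)cc2-c2nc3cc(Cl)ccc3[nH]2)cc1`: > 50000 nM, a limit

Compound 3 sits at the limit of > 50000 nM in this assay, at which 2 of the 3 values shown sit. The change to compound 4 `Fc1ccc(-c2nn(-c3ccccc3)cc2-c2nc3cc(Cl)c(Cl)cc3[nH]2)cc1` is chloro in place of hydrogen on an aromatic carbon. The same replacement appears in one measured step, an at least 1.6-fold lower number from compound 1 to compound 2 (0.22 log units; that floor lies within the scatter). The fluoro step, a step that the two limits leave unreadable from compound 1 to compound 3, gives no size. A lower number is therefore expected in this assay, small and possibly none beyond the scatter. The expected step is an at least 1.6-fold lower number from compound 3 to compound 4 (0.22 log units; that floor lies within the scatter). The closest number is that of compound 2 at 29700 nM. Compound 4 is estimated at 30000 nM, with an expected range of 13000 nM to 50000 nM.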

Compound 4, half-maximal inhibitory concentration: 44600 nM
Compound 4: middle estimate off by 1.5-fold (0.17 log units), on the low side; the measured number falls inside the stated range.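

Compound 4 adds a second case of chloro in place of hydrogen, here ortho to a chloro group, in this assay, with an at least 1.1-fold lower number from compound 3 to compound 4 (0.04 log units; that floor lies within the scatter). Neither floor passes the scatter: the same change on two cores in this assay, an at least 1.6-fold lower number (0.22 log units; that floor lies within the scatter) from compound 1 to compound 2 and an at least 1.1-fold lower number (0.04 log units; that floor lies within the scatter) from compound 3 to compound 4; the limit leaves it open whether they differ

The fluoro change, unreadable on the earlier pair, now has a size on the core with both chloro groups, with a 1.5-fold higher number from compound 2 to compound 4 (0.18 log units; within the scatter).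

Compound 1 and compound 3 each stand at a limit, so the full size of both chloro steps stays open: the limit of > 50000 nM in this assay, at which 2 of the 4 values shown sit.

Also open, as far as these compounds go, is how an amine or a carboxylic acid on this aromatic carbon would read in this assay.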